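The compounds below may be only part of what the source reports. "The series", "measured", "known", "first", "only" and "open" are said of these compounds alone.

Compound 2, `Nc1cc(N)c2nc(-c3ccccc3)c(Sc3ccc(F)cc3)nc2c1`, carries a 4-fluorophenyl on the sulfur attached to the shared core. In a functional assay on SR cells (Homo sapiens) for inhibition, read by sulforhodamine B assay, with a stated time of 48 h (a higher number here means a weaker inhibitor of growth, a lower number a stronger inhibitor of growth), compound 2 gives only a limit, < 100000 nM, and no number. Compound 3, `COc1cc(CNc2nc3cc(N)cc(N)c3nc2-c2ccccc2)cc(OC)c1OC`, likewise gives only a limit in this assay, < 50200 nM. For the measured compounds named here, the one firm number comes from compound 1, `Nc1cc(N)c2nc(-c3ccccc3)c(NCc3ccc(Cl)c(Cl)c3)nc2c1`, which gives 6030 nM in this assay. Compound 4, `Nc1cc(N)c2nc(-c3ccccc3)c(Sc3ccc(Cl)c(Cl)c3)nc2c1`, has not been measured; it differs from compound 2 by 3,4-dichlorophenyl in place of 4-fluorophenyl on a sulfur. Going by the values given here, no comparable step between measured compounds exists, so the direction rests on compound 1 alone, whose 3,4-dichlorophenyl-bearing side chain gave 6030 nM. The expected step from compound 2 to compound 4 is a step that the limit leaves unreadable from compound 2 to compound 4, toward stronger growth inhibition. Compound 4 is estimated at 15000 nM, between 3000 nM and 80000 nM.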

Compound 4, concentration for total growth inhibition: 35500 nM
For compound 4 the middle estimate is 2.4-fold (0.37 log units) below the measured one; low and high end bracket the measured number.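

No step can be read from compound 2 to compound 4, since compound 2 gives only a limit in this assay: the limit of < 100000 nM in this assay, at which 1 of the 4 values shown sits.

The compounds shown leave open whether 3,4-dichlorophenyl in place of 4-fluorophenyl on a sulfur changes growth inhibition at all.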